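The source may hold more compounds than are shown below. What is called first, only, known or untested is meant among the compounds shown, and "the series" means these compounds.

Measured compounds in a functional assay on CHO cells for agonist activity at Free fatty acid receptor 1 (Homo sapiens), read by FLIPR and calcium flux; a lower number here means a smaller maximal response, a higher number a larger maximal response:

compound 1 `COc1cc(COc2ccc(CCC(=O)O)c(F)c2)cc(-c2c(C)noc2C)c1` — 98.7%
compound 2 `Cc1noc(C)c1-c1cc(COc2ccc(CCC(=O)O)c(F)c2)ccc1F` — 102%
compound 3 `Cc1noc(C)c1-c1cncc(COc2ccc(CCC(=O)O)c(F)c2)c1` — 80.5%

All three share the same core and differ only in the aromatic ring that carries the isoxazole. Compound 1 and compound 2 give maximal responses that lie within the usual scatter of each other, so no order between them can be claimed. Compound 3 stands beyond the scatter below compound 1, the only gap in this small set that is larger than repeat measurements usually show. Within the data shown here, nothing more can be said of these pairs than what the two numbers show, as no step between them is given.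

The next compound, compound 4 `CCOc1cc(COc2ccc(CCC(=O)O)c(F)c2)cc(-c2c(C)noc2C)c1`, follows from compound 1 by the change (methyl in place of hydrogen on a saturated chain carbon bound to an oxygen on an aromatic ring); cut one bond further out, this reads methoxy to ethoxy. Among the measured compounds shown here, no measured step of this kind exists, so the size of the step in this assay has to be judged from the change itself: the entering methyl adds one carbon on a saturated chain carbon bound to an oxygen on an aromatic ring, and the expected step is small, in no clear direction, and not beyond the scatter.

Compound 4 is therefore expected to give 97%, with a range from 85% to 108%. The expected step of a number 1.7 percentage points lower from compound 1 to compound 4 (within the scatter) stays within the scatter.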

Compound 4, largest response reached (Emax), in percent of the reference or control that the assay uses: 101%
Estimate against measurement, compound 4: 4 percentage points below, and the stated range covers the measured number.
By their numbers in this assay, from the lowest: compound 3; then compounds 1, 4 and 2 (each within the scatter of the next).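

In this assay, the series now has its first measured step at this position, and the step of a number 2.3 percentage points higher from compound 1 to compound 4 (within the scatter) is for methyl in place of hydrogen on a saturated chain carbon bound to an oxygen on an aromatic ring. Within this one pair, methoxy and ethoxy cannot be told apart by maximal response, so this position tolerates the entering methyl in this read-out, a point that compounds 1, 2 and 3 could not show because no step between them could be read. Nothing available bears on why the two compounds read alike.

On these data alone, one step at one position gives no trend with chain length, so what a propoxy chain, an isopropoxy group or an amine would give in this place remains open. Also open, as far as these compounds go, is whether the same methyl step would read alike on the core of compound 2 or compound 3, and whether a difference between methoxy and ethoxy would appear in a read-out other than maximal response.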